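Removing a Ring Fluorine from a Naphthyl Sugar Analogue

The source may hold more compounds than are shown below. What is called first, only, known or untested is meant among the compounds shown, and "the series" means these compounds.

Compounds measured so far:
Compound 1, `O[C@@H]1[C@@H](F)[C@H](Oc2ccc3ccccc3c2)OC[C@H]1O`: 22 uM
Compound 2, `O[C@H]1[C@H](Oc2ccc3ccccc3c2)OCC[C@@H]1O`: 284 uM

Both compounds were tested in a functional assay on HCC70 cells (Homo sapiens) for antiproliferative activity, read by crystal violet staining, with a stated time of 96 h; on this read-out higher numbers stand for an effect only at larger amounts of compound and lower numbers for an effect already at smaller amounts. Compound 1 gives the lowest of the two numbers, with 22 uM, while compound 2 sits far higher at 284 uM, a gap well beyond the usual scatter. Compound 2 differs from compound 1 in more than one place, so the two values are only compared, not traced to one change.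

Compound 3, `O[C@@H]1CO[C@@H](Oc2ccc3ccccc3c2)C[C@H]1O`, has not yet been measured. Among the measured compounds shown here, its only difference from compound 1 is hydrogen in place of fluoro on a saturated ring carbon. For the measured compounds named here, since no pair of measured compounds shows this change alone, its effect is open. The expectation is a modest step toward a higher number, a 2.0-fold higher number from compound 1 to compound 3 (0.31 log units; beyond the scatter), possibly no larger than the scatter. Compound 3 is estimated at 45 uM, within a range from 15 uM to 150 uM.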

Compound 3, concentration for half-maximal effect: 228 uM
Beside the measured number, compound 3's estimate is 5.1-fold (0.70 log units) below it, and the stated range ends below it.
By their numbers in this assay, from the lowest: compound 1; then compounds 3 and 2 (each within the scatter of the next).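

Among the compounds shown here, measured in this assay this pair isolates a single change for the first time: hydrogen in place of fluoro gives a 10-fold higher number from compound 1 to compound 3 (1.02 log units; beyond the scatter) and so marks a large step. One fluorine atom on this saturated ring carbon, which lies next to the ring atom that bears a hydroxy group and next to the ring atom that bears a large group, therefore makes a clear difference to the number on the shared core. No measurement is available that accounts for the size of this step.

As far as these compounds go, whether another small group on this carbon, such as chlorine, a methyl group or an amine, would keep the lower number of compound 1 remains open. From the compounds shown here alone, it is also open whether the same swap would produce a step of similar size elsewhere on the core.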